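The source may report more compounds than this note shows. Statements on the series, on what has been measured and on what is new or still open speak of the compounds shown alone.

In a functional assay on HT-29 cells (Homo sapiens) for antiproliferative activity, read by sulforhodamine B assay, with a stated time of 48 h (a higher number here means a weaker inhibitor, a lower number a stronger inhibitor), compound 2 `CCc1ccc(NS(=O)(=O)c2ccc(N3CCNC3=O)cc2)cc1` gives 660 nM and compound 1 `CCCCc1ccc(NS(=O)(=O)c2ccc(N3CCNC3=O)cc2)cc1` gives 610 nM, so the two values lie within the scatter of each other. Compound 3 `CC(C)(C)c1ccc(NS(=O)(=O)c2ccc(N3CCNC3=O)cc2)cc1` has tert-butyl in place of ethyl on an aromatic carbon. Among the compounds with values here, the only measured step bearing on this change is a 1.1-fold higher number from compound 1 to compound 2 (0.03 log units; within the scatter). Within the data shown here, it alters the same substituent and is small, so no step beyond the scatter is expected in this assay, although no measured compound carries tert-butyl. The expected step is a 1.1-fold lower number from compound 2 to compound 3 (0.04 log units; within the scatter). For compound 3 the estimated value is 600 nM, with an expected range of 250 nM to 1400 nM.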

Compound 3, half-maximal inhibitory concentration: > 1000 nM
Compound 3: a limit, no number; the forecaster's own chance of this, stated with the estimate: 1%; at least 1.6-fold (0.22 log units) between middle value and limit.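

In this assay compound 3 gives > 1000 nM, which is a limit of the assay and not a number. Tert-butyl on this aromatic carbon, para to a large group, gives only floors, an at least 1.5-fold higher number from compound 2 to compound 3 (0.18 log units; that floor lies within the scatter) and an at least 1.6-fold higher number from compound 1 to compound 3 (0.21 log units; that floor lies within the scatter), so it cannot yet be separated from ethyl or butyl, though a real loss is not excluded. The true size of both steps stays unknown because the reading ends at a limit: the limit of > 1000 nM in this assay, at which 1 of the 3 values shown sits.

Going by these compounds, whether tert-butyl is truly weaker than ethyl or butyl remains open. On these data alone, how a methoxy group or a carboxylic acid would read at this position is also open.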